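The source may report more compounds than this note shows. Statements on the series, on what has been measured and on what is new or still open speak of the compounds shown alone.

Of the compounds shown here, two with a shared core have been measured in a functional assay on KBVIN cells (Homo sapiens) for cytotoxicity, read by MTT assay, with a stated time of 72 h; a lower number here means that less compound is needed, a higher number that more compound is needed for the effect. Compound 1 `CCCCCc1cc(Nc2ccc(OC)cc2)cc(=O)o1` gives 4.84 uM in this assay. Compound 2 `Cc1ccc(Nc2cc(-c3ccccc3)oc(=O)c2)cc1` gives 0.059 uM in this assay, the lowest of the two numbers; its nearest neighbour is compound 1, whose number is higher by a margin that lies beyond the scatter. Within the data shown here, compound 1 and compound 2 differ in more than one place, so the two values show only that compound 2 needs far less compound for the effect than compound 1, and no single change can be credited for the gap.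

Compound 3 `COc1ccc(Nc2cc(-c3ccccc3)oc(=O)c2)cc1` has not yet been measured in this assay. It is reached from compound 2 by one change: methoxy in place of methyl on an aromatic carbon. Among the measured compounds shown here, no pair of measured compounds isolates this change, so its size is not known from the data. The expectation is a small step, a 1.4-fold higher number from compound 2 to compound 3 (0.13 log units; within the scatter), in either direction or none beyond the scatter. Compound 3 is therefore expected to give about 0.08 uM in this assay, with a likely range from 0.02 uM to 0.4 uM.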

Compound 3, concentration for half-maximal effect: 0.098 uM
Estimate against measurement, compound 3: 1.2-fold (0.09 log units) below, and the stated range covers the measured number.
By their numbers in this assay, from the lowest: compounds 2 and 3 (each within the scatter of the next); then compound 1.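

In this assay, methoxy in place of methyl on an aromatic carbon, para to a large group, gives a 1.7-fold higher number from compound 2 to compound 3 (0.22 log units; within the scatter), so the two groups cannot be told apart at this position, although methoxy brings one more heavy atom and a hydrogen-bond acceptor. Among these compounds, compound 3 also shares its methoxy group with compound 1, which isolates the other place for the first time: phenyl in place of pentyl gives a 49-fold lower number from compound 1 to compound 3 (1.69 log units; beyond the scatter), so the large gap between compound 1 and compound 3 belongs to that single exchange. No measured property is at hand that would explain either step.

The compounds shown leave open whether a hydroxyl group, a chlorine atom or an amine at the same place on the ring would also stay within the scatter of methyl and methoxy. They also leave open how a shorter chain such as propyl, or a benzyl group, would fall in this assay relative to the pentyl and phenyl groups at the other place.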